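From Difluorophenyl to Bromophenyl on the Terminal Amide Nitrogen

The source may report more compounds than this note shows. Statements on the series, on what has been measured and on what is new or still open speak of the compounds shown alone.

In a functional assay on MDA-MB-231 cells (Homo sapiens) for cytotoxicity, read by MTT assay, with a stated time of 72 h (on this read-out higher numbers stand for weaker inhibition and lower numbers for stronger inhibition), compound 2 `COc1cc2c(Oc3ccc(/C=N/NC(=O)Nc4ccc(F)c(F)c4)cc3F)ccnc2cc1OCCCN1CCCCC1` gives 960 nM, the lowest of the two numbers measured, and compound 1 `COc1cc2c(Oc3ccc(/C=N/NC(=O)Nc4ccccc4)cc3F)ccnc2cc1OCCCN1CCCCC1` stands nearest with 1200 nM. The step of a 1.3-fold lower number from compound 1 to compound 2 (0.10 log units; within the scatter) lies within the scatter. Compound 3 `COc1cc2c(Oc3ccc(/C=N/NC(=O)Nc4ccc(Br)cc4)cc3F)ccnc2cc1OCCCN1CCCCC1` differs from compound 2 by 4-bromophenyl in place of 3,4-difluorophenyl on an amide-type nitrogen. Going by the values given here, the one measured step that bears on this change, a 1.3-fold lower number from compound 1 to compound 2 (0.10 log units; within the scatter), was small, so in this assay compound 3 is expected to show no step beyond the scatter, a 1.0-fold lower number from compound 2 to compound 3 (0.00 log units; within the scatter). Compound 3 is therefore estimated at 950 nM, with a range from 450 nM to 2000 nM.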

Compound 3, half-maximal inhibitory concentration: 800 nM
The estimate for compound 3 lay 1.2-fold (0.07 log units) above the measured number, within the range that was stated.
By their numbers in this assay, from the lowest: compounds 3, 2 and 1 (each within the scatter of the next).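

In this assay the change to 4-bromophenyl gave a 1.2-fold lower number from compound 2 to compound 3 (0.08 log units; within the scatter) and the comparison with the unsubstituted phenyl gave a 1.5-fold lower number from compound 1 to compound 3 (0.18 log units; within the scatter), so a bromine on this ring, like two fluorines, moved the number by no more than the scatter. Phenyl, 3,4-difluorophenyl and 4-bromophenyl on the amide-type nitrogen thus stand within the scatter of one another. No measurement at hand explains this.

The compounds shown carry only halogens on this ring. Going by these compounds, whether an amine, a carboxylic acid or a methoxy group there, or a longer chain in place of the ring, would give a step beyond the scatter remains open.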